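Enantiomer step from compound 2 to compound 3

The source may hold more compounds than are shown below. What is called first, only, known or untested is meant among the compounds shown, and "the series" means these compounds.

Measured so far:
compound 1 `CC(NC(=O)C(=O)Nc1c(C#N)cnn1-c1ccccc1)c1ccccc1` — 50%
compound 2 `C[C@@H](NC(=O)C(=O)Nc1c(C#N)cnn1-c1ccccc1)c1ccccc1` — 50%

Compound 2, the R configuration at the saturated chain carbon, stands level with compound 1 in a functional assay on the whole organism (strain Wistar albino) for inhibition, with Rattus norvegicus as the target, read by paw edema, in the formalin test, with stated times of 1 h and 4 h, at a dose of 20 mg/kg by the oral route; on this read-out higher numbers stand for more inhibition at the one dose given (going by the name of the read-out) and lower numbers for less inhibition: the step of no change at the digits printed from compound 1 to compound 2 (within the scatter) shows no change, and the only distinction between them is that (the fact that one of compounds 1 and 2 is drawn with a defined configuration and the other without, at the place where they differ). Compound 1 is drawn without a configuration at that centre and behaves in this assay no differently from the single R form.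

Compound 3 `C[C@H](NC(=O)C(=O)Nc1c(C#N)cnn1-c1ccccc1)c1ccccc1` is not yet measured. Its change from compound 2 is the two compounds have the same atoms and bonds and differ only in configuration as drawn: 1 of 1 stereo elements differ; a stereocentre at a saturated chain carbon is drawn R in compound 2 and S in compound 3.

Among the measured compounds shown here, the one measured step that bears on this change is the step from the undefined centre to the R form, which lay within the scatter. If the undefined material holds both forms, the S form would be expected to sit near the R form as well, although a single step of this kind cannot exclude a difference between the two enantiomers. The step of a number 5 percentage points lower from compound 2 to compound 3 (within the scatter) is therefore expected to be small, with a slightly wider range than usual. Compound 3 is estimated at 45%, with a range from 25% to 65%.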

Compound 3, a percentage reported as inhibition, in the whole organism at one dose (the size of the read-out at that dose, not a potency): 39%
Beside the measured number, compound 3's estimate is 6 percentage points above it, within the range that was stated.
By their numbers in this assay, from the lowest: compound 3; then compounds 1 and 2 (each within the scatter of the next).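

In this assay the configuration drawn at the saturated chain carbon now shows an effect, with a number 11 percentage points lower from compound 2 to compound 3 (beyond the scatter), and this step rests on a single structural difference: the fact that compounds 2 and 3 differ only in the configuration as drawn. The same gap appears against the material drawn without a configuration, with a number 11 percentage points lower from compound 1 to compound 3 (beyond the scatter) set against no change at the digits printed from compound 1 to compound 2 (within the scatter), so the S form separates from the other two, which the first pair alone could not show: the fact that one of compounds 1 and 3 is drawn with a defined configuration and the other without, at the place where they differ. The effect of this centre is modest rather than all-or-none, since compound 3 still gives 39% in this assay.

Going by these compounds, the three compounds share the same atoms and bonds, and each has a single reading at one dose, so it remains open whether the gap between the R and S forms holds at other doses or reflects a difference in potency. On these data alone, it also remains open how this centre would behave with a different group on it, such as an ethyl group or a carboxylic acid, and whether the preference for the R form would carry over to such compounds.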